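The source may report more compounds than this note shows. Statements on the series, on what has been measured and on what is new or still open speak of the compounds shown alone.

Measured so far:
compound 1 `O=C(CN1CN(c2ccccc2)C2(CCN(C(=O)c3ccc(C4CCCCC4)cc3)CC2)C1=O)N1CCCCC1` — 1100 nM
compound 2 `CC(C)(C)OC(=O)NC1CCCN(C(=O)CN2CN(c3ccccc3)C3(CCN(C(=O)c4ccc(C(C)(C)C)cc4)CC3)C2=O)C1` — 4200 nM
compound 3 `CC1CCCN(C(=O)CN2CN(c3ccccc3)C3(CCN(C(=O)c4ccc(C5CCCCC5)cc4)CC3)C2=O)C1` — 3600 nM

All three share one core and were tested in an assay on HEK293 cells for displacement of a labelled ligand from NPC1-like intracellular cholesterol transporter 1 (Homo sapiens); a lower number here means a stronger inhibitor, a higher number a weaker inhibitor. Compound 3 stands second highest of the three numbers. Its nearest neighbour is compound 2, whose value lies within the scatter of compound 3, so no order between those two can be claimed. Compound 1 is furthest away: the step of a 3.3-fold higher number from compound 1 to compound 3 (0.51 log units; beyond the scatter) is beyond the scatter.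

Compound 4 `CC(C)(C)OC(=O)NC1CCCN(C(=O)CN2CN(c3ccccc3)C3(CCN(C(=O)c4ccc(C5CCCCC5)cc4)CC3)C2=O)C1` is the next compound in this assay. It differs from compound 3 by (tert-butoxycarbonyl)amino in place of methyl on a saturated ring carbon. Among the measured compounds shown here, no measured pair shows this exact exchange. For the measured compounds named here, the only step that bears on the same ring carbon is a 3.3-fold higher number from compound 1 to compound 3 (0.51 log units; beyond the scatter), which shows that a change at this position can move the number, though only modestly. The same (tert-butoxycarbonyl)amino group on that ring carbon is carried by compound 2, which differs from compound 4 elsewhere; in this assay compound 2 gives 4200 nM, close to the value of compound 3.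

On this basis compound 4 is expected to stay near compound 3, with a step of a 1.0-fold lower number from compound 3 to compound 4 (0.01 log units; within the scatter) that would lie within the scatter. The estimate for compound 4 is 3500 nM, with a range from 1500 nM to 8000 nM.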

Compound 4, half-maximal inhibitory concentration: 4400 nM
Estimate against measurement, compound 4: 1.3-fold (0.10 log units) below; the measured number falls inside the stated range.
By their numbers in this assay, from the lowest: compound 1; then compounds 3, 2 and 4 (each within the scatter of the next).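

In this assay the exchange of methyl for (tert-butoxycarbonyl)amino, which brings 8 heavy atoms in place of 1 on the saturated ring carbon, gives no change that can be read (a 1.2-fold higher number from compound 3 to compound 4 (0.09 log units; within the scatter)). Compound 4 still stands apart from the hydrogen-bearing compound 1 (a 4.0-fold higher number from compound 1 to compound 4 (0.60 log units; beyond the scatter)), so across compounds 1, 3 and 4 both substituents at this carbon go with a higher number than hydrogen, while methyl and (tert-butoxycarbonyl)amino cannot be ordered against each other. With (tert-butoxycarbonyl)amino held in place, cyclohexyl in place of tert-butyl on the aromatic carbon also gives no readable change (a 1.0-fold higher number from compound 2 to compound 4 (0.02 log units; within the scatter)), so this pair offers no sign that the aromatic substituent alters the result in this series.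

The compounds shown leave open whether a free amine, a hydroxyl or a carboxylic acid on the same ring carbon would stay with compounds 3 and 4 or come closer to compound 1. Nothing given here explains why the hydrogen-bearing compound 1 stands apart from the substituted compounds.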